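Chain Extension at the Terminal Carbon of the Alkyl Series

The compounds below may be only part of what the source reports. "The series", "measured", "known", "first", "only" and "open" are said of these compounds alone.

Two compounds of the series have numbers in a functional assay on HEK293 cells for agonist activity at G-protein coupled receptor 84 (Homo sapiens), read by calcium flux; a higher number here means that more compound is needed for the effect, a lower number that less compound is needed. Compound 1 `CC(C)CCCc1nc(O)cc(O)n1` carries a branched chain and in this assay gives 2110 nM. Compound 2 `CCCCCCCc1nc(O)cc(O)n1` carries a straight chain and in this assay gives 12.7 nM. Going by the values given here, the single measured step, a 170-fold lower number from compound 1 to compound 2 (2.22 log units; beyond the scatter), shows that the shape and length of the chain weigh heavily in this assay. Among the compounds with values here, compound 2 therefore stands at the lowest of the two numbers, with compound 1 as its only neighbour.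

Compound 3 `CCCCCCCCc1nc(O)cc(O)n1` differs from compound 2 by methyl in place of hydrogen on a saturated chain carbon, seven bonds along the chain from an aromatic carbon. Within the data shown here, the measured step bears on it only loosely: it compares branched against straight rather than straight against one carbon longer, and no pair showing a bare terminal extension exists here. Because of a 170-fold lower number from compound 1 to compound 2 (2.22 log units; beyond the scatter) a change of chain length at the end is unlikely to be neutral, yet its direction cannot be read from one step. The expectation for compound 3 in this assay is 8 nM, within 2 nM to 40 nM. Against compound 2 this corresponds to an expected step of a 1.6-fold lower number from compound 2 to compound 3 (0.20 log units; within the scatter).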

Compound 3, half-maximal effective concentration: 11.4 nM
Estimate against measurement, compound 3: 1.4-fold (0.15 log units) below; the range from low to high includes it.
By their numbers in this assay, from the lowest: compounds 3 and 2 (each within the scatter of the next); then compound 1.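

In this assay, methyl in place of hydrogen on a saturated chain carbon, seven bonds along the chain from an aromatic carbon, gives a 1.1-fold lower number from compound 2 to compound 3 (0.05 log units; within the scatter), so this position takes the added carbon with no change that can be separated from the scatter. Going by these compounds alone, this is the first bare extension at the chain end, and it sets compound 2 and compound 3 level, while pentyl in place of isopropyl, three bonds along the chain from an aromatic carbon, still gives a 190-fold lower number from compound 1 to compound 3 (2.27 log units; beyond the scatter), so the one large gap remains the one that sets compound 1 apart from the straight chains. Nothing on hand gives a reason for the flat step at the chain end.

The compounds shown leave open how far this level stretch runs: a longer chain such as decyl, or a chain ending in a carboxylic acid or an amine, would test whether the chain end stays this permissive. Shorter straight chains such as butyl also remain open, so the share of chain length and the share of branching in the gap to compound 1 cannot yet be told apart.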